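The source may hold more compounds than are shown below. What is called first, only, known or untested is meant among the compounds shown, and "the series" means these compounds.

Measured so far in a functional assay on HCT-116 cells (Homo sapiens) for cytotoxicity, read by MTT assay, with a stated time of 72 h; on this read-out lower numbers stand for stronger inhibition and higher numbers for weaker inhibition:

Compound 1, `c1ccc(NN=C(c2nc3ccccc3[nH]2)c2nc3ccccc3[nH]2)cc1`: 17600 nM
Compound 2, `Cc1ccc(NN=C(c2nc3ccccc3[nH]2)c2nc3ccccc3[nH]2)cc1`: 10500 nM
Compound 3, `COc1ccc(NN=C(c2nc3ccccc3[nH]2)c2nc3ccccc3[nH]2)cc1`: 66500 nM

Among these three, compound 1 stands second highest. Compound 2 lies nearest, with a 1.7-fold lower number from compound 1 to compound 2 (0.22 log units; within the scatter), a gap that does not exceed the scatter. Compound 3 lies furthest, with a 3.8-fold higher number from compound 1 to compound 3 (0.58 log units; beyond the scatter), a modest worsening that does exceed it. Between the two substituted compounds there is a 6.3-fold higher number from compound 2 to compound 3 (0.80 log units; beyond the scatter).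

The next compound, compound 4, is `O=[N+]([O-])c1ccc(NN=C(c2nc3ccccc3[nH]2)c2nc3ccccc3[nH]2)cc1`. It differs from compound 1 by nitro in place of hydrogen on an aromatic carbon. Among the compounds with values here, no measured step carries a nitro group, so none bears directly on this change. The closest guides are the two substitutions at the same place on the ring: methyl, which moved the number by a 1.7-fold lower number from compound 1 to compound 2 (0.22 log units; within the scatter), and methoxy, which moved it by a 3.8-fold higher number from compound 1 to compound 3 (0.58 log units; beyond the scatter). One stayed within the scatter; the other was a modest rise. A nitro group resembles neither, so the expectation rests on thin ground.

Compound 4 is therefore expected to land close to compound 1, with the estimated step of a 1.2-fold lower number from compound 1 to compound 4 (0.07 log units; within the scatter). The estimate for compound 4 is 15000 nM, with a range from 5000 nM to 45000 nM.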

Compound 4, half-maximal inhibitory concentration: 4700 nM
Compound 4: the middle estimate sits 3.2-fold (0.50 log units) above what was measured, and the stated range ends above it.
By their numbers in this assay, from the lowest: compound 4; then compounds 2 and 1 (each within the scatter of the next); then compound 3.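

In this assay, the aromatic carbon para to a large group now shows that a substituent there can lower the number beyond the scatter, as nitro in place of hydrogen gives (a 3.7-fold lower number from compound 1 to compound 4 (0.57 log units; beyond the scatter)). Within the data shown here, until now, the only step beyond the scatter from compound 1 was the rise with methoxy in compound 3, while methyl in compound 2 stayed within the scatter, so this place can move the number in either direction, depending on the group. The direct swaps at this place give (a 14-fold lower number from compound 3 to compound 4 (1.15 log units; beyond the scatter)) and (a 2.2-fold lower number from compound 2 to compound 4 (0.35 log units; beyond the scatter)), which makes compound 4, the 4-nitrophenyl member, the most potent of the four, although no measured property of these groups is at hand to explain the order.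

From the compounds shown here alone, with only methyl, methoxy and nitro at this place, it remains open whether an amine, a carboxylic acid or a chlorine atom would follow nitro or methoxy. Going by these compounds, it is also open whether the lower number of compound 4 is tied to this place or would hold with nitro on another carbon of the same ring.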